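A few compounds are considered here, and "the series" means these few. Any claim that something is new, unique, unknown or untested is made for them only; others in the source may bear on it.

For the measured compounds named here, compound 2, `Cc1ccc(Nc2nnc(Nc3nc(-c4ccc(Br)cc4)cs3)s2)cc1`, is one of two compounds measured in a functional assay on the whole organism (strain albino) with Mus musculus as the target, with a stated time of 0.5 h; a higher number here means that more compound is needed for the effect, a lower number that less compound is needed; in this assay compound 2 gives 300 mg/kg, the higher of the two numbers. Compound 1, `COc1ccc(Nc2nnc(Nc3nc(-c4ccc(Cl)cc4)cs3)s2)cc1`, gives 100 mg/kg in this assay, the lower number; compound 1 and compound 2 differ in more than one place, so their two values are recorded side by side without a single step between them. Compound 3, `COc1ccc(Nc2nnc(Nc3nc(-c4ccc(Br)cc4)cs3)s2)cc1`, has not yet been measured in this assay. It differs from compound 2 by a single change: methoxy in place of methyl on an aromatic carbon, a difference that sits on the (4-methylphenyl)amino part, which becomes (4-methoxyphenyl)amino. Because compound 1, which also carries the methoxy, gives 100 mg/kg, the expected step from compound 2 to compound 3 is a modest move toward a lower number, a 2.0-fold lower number from compound 2 to compound 3 (0.30 log units; within the scatter), only just beyond the scatter. The estimate for compound 3 in this assay is 150 mg/kg, with a range from 75 mg/kg to 300 mg/kg.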

Compound 3, minimum effective dose: 100 mg/kg
The estimate for compound 3 lay 1.5-fold (0.18 log units) above the measured number; measured number inside the range.
By their numbers in this assay, from the lowest: compounds 1 and 3 (each within the scatter of the next); then compound 2.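

In this assay, methoxy in place of methyl on an aromatic carbon, para to a large group, gives a 3.0-fold lower number from compound 2 to compound 3 (0.48 log units; beyond the scatter), so this position responds to the change by more than the scatter, something the earlier pair, which differed in more than one place, could not show. Bromo in place of chloro, by contrast, gives no change at the digits printed from compound 1 to compound 3 (within the scatter), so with methoxy present the two halogens are not told apart in this assay. Nothing available explains the effect of the methoxy group at this position.

The compounds shown leave open whether the methoxy step would be the same with chloro in place of bromo. They also leave open how this position would respond to an amine, a hydroxyl or a longer chain such as ethoxy.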